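Bromo for Chloro on the Most Active Stereoisomer

This account rests on a few compounds, and the source may have more. Where it says the series, first, only, none or still open, it means among the compounds named here.

Measured compounds:
compound 1 `CC#C[C@@H](CC(=O)O)c1ccc(OC[C@H]2COc3ccc(Cl)cc3O2)cc1` gives 86%
compound 2 `CC#C[C@H](CC(=O)O)c1ccc(OC[C@H]2COc3ccc(Cl)cc3O2)cc1` gives 47%
compound 3 `CC#C[C@@H](CC(=O)O)c1ccc(OC[C@@H]2COc3ccc(Cl)cc3O2)cc1` gives 65%

All three were tested in a functional assay on HEK293 cells for agonist activity at Free fatty acid receptor 1 (Homo sapiens), read by fluorescence and calcium flux, with a stated time of 10 min; on this read-out higher numbers stand for larger maximal responses and lower numbers for smaller maximal responses. Compound 1 stands highest of the three: the step of a number 39 percentage points lower from compound 1 to compound 2 (beyond the scatter) and the step of a number 21 percentage points lower from compound 1 to compound 3 (beyond the scatter) are both beyond the scatter, so compound 1 can be called the most active of the measured set. These steps come from changes of configuration only the fact that compounds 1 and 2 differ only in the configuration as drawn (the fact that compounds 1 and 3 differ only in the configuration as drawn); the same holds for the step of a number 18 percentage points higher from compound 2 to compound 3 (beyond the scatter) (the fact that compounds 2 and 3 differ only in the configuration as drawn).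

Compound 4 `CC#C[C@@H](CC(=O)O)c1ccc(OC[C@H]2COc3ccc(Br)cc3O2)cc1` keeps the configuration of compound 1 and changes a single atom instead: bromo in place of chloro on an aromatic carbon. Among the measured compounds shown here, none of the measured steps involves a change of this kind, so they give no direct guide to its size or direction. Without any comparable step to lean on, the expectation is a step of a number 2 percentage points lower from compound 1 to compound 4 (within the scatter) that stays within the scatter. Compound 4 is therefore estimated at 84% in this assay, with a range from 65% to 100%.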

Compound 4, largest response reached (Emax), in percent of the reference or control that the assay uses: 69%
Compound 4: the middle estimate sits 15 percentage points above what was measured; the range from low to high includes it.
By their numbers in this assay, from the lowest: compound 2; then compounds 3 and 4 (each within the scatter of the next); then compound 1.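

Bromo in place of chloro on this aromatic carbon is not a neutral exchange in this assay: the swap gives a number 17 percentage points lower from compound 1 to compound 4 (beyond the scatter). The earlier compounds shown here showed that the maximal response depends on configuration, and this pair shows that it also depends on which halogen sits at this position, even though the count of hydrogen-bond donors and acceptors and the net charge stay the same. Compound 1, with chloro, remains the most active of the four compounds.

Nothing shown here accounts for the lower response that comes with bromo. Going by these compounds, it also remains open whether fluoro, methyl or a nitrile at the same position would keep the response of compound 1, and whether the other stereoisomers would react to bromo in the same way.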